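The source may hold more compounds than are shown below. What is called first, only, known or untested is meant among the compounds shown, and "the series" means these compounds.

In a functional assay on DU-145 cells (Homo sapiens) for cytotoxicity, read by trypan blue exclusion, with a stated time of 96 h (on this read-out higher numbers stand for weaker inhibition and lower numbers for stronger inhibition), the measured compounds are:
compound 1 `COc1ccc(/C=C/S(=O)(=O)Cc2ccc(OC)c(N)c2)cc1` gives 2500 nM;
compound 2 `COc1cc(OC)c(/C=C/SCc2ccc(OC)c(N)c2)c(OC)c1` gives 50 nM;
compound 3 `COC(=O)CCNc1cc(CS(=O)(=O)/C=C/c2c(OC)cc(OC)cc2OC)ccc1OC` gives 1500 nM.

Compound 3 holds the second highest of the three numbers in this assay. Its nearest neighbour is compound 1, whose number is higher by a gap within the scatter; its furthest is compound 2, whose number is lower by a gap beyond the scatter. Compound 4 `COc1cc(OC)c(/C=C/S(=O)(=O)Cc2ccc(OC)c(NC(C(=O)O)c3ccc(Cl)cc3)c2)c(OC)c1` has not yet been measured. It differs from compound 3 in one place: carboxy(4-chlorophenyl)methyl in place of 2-(methoxycarbonyl)ethyl on a nitrogen on an aromatic ring. Within the data shown here, no measured pair shows the effect of such a change, so the step expected in this assay is a 1.3-fold lower number from compound 3 to compound 4 (0.10 log units; within the scatter), which is expected to stay within the scatter, with no sure direction. On that basis compound 4 is estimated at 1200 nM in this assay, with a range from 300 nM to 5000 nM.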

Compound 4, half-maximal inhibitory concentration: 400 nM
For compound 4 the middle estimate is 3.0-fold (0.48 log units) above the measured one; measured number inside the range.
By their numbers in this assay, from the lowest: compound 2; then compound 4; then compounds 3 and 1 (each within the scatter of the next).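

In this assay, among these compounds, replacing the 2-(methoxycarbonyl)ethyl on the nitrogen with carboxy(4-chlorophenyl)methyl gives a 3.8-fold lower number from compound 3 to compound 4 (0.57 log units; beyond the scatter), the first step that can be read at this position. It shows that this nitrogen can carry the larger group, with its six-membered aromatic ring, without the number rising. Nothing available explains the step.

The compounds shown leave open whether the carboxylic acid, the chlorine or the aromatic ring accounts for the step, and whether a methyl ester in place of the carboxylic acid would keep it.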